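The source may hold more compounds than are shown below. What is called first, only, known or untested is meant among the compounds shown, and "the series" means these compounds.

Compound 1 `CC(C)Oc1cc(=O)oc2cc(OCc3cccc(Cl)c3)ccc12` gives 3%
Compound 2 `O=c1cc(CO)c2ccc(OCc3cccc(Br)c3)cc2o1` gives 49%

Both numbers come from an assay on isolated protein (strain Sprague-Dawley) for inhibition of Amine oxidase [flavin-containing] A (Rattus norvegicus), read by spectrophotometry, with a stated time of 5 min, tested at 10 uM; on this read-out lower numbers stand for less inhibition and higher numbers for more inhibition at the one concentration tested (going by the name of the read-out). Among the compounds with values here, compound 1 stands lowest of the two; compound 2 lies a good deal higher, by a gap beyond the usual scatter, but no single-change step joins these two compounds, so only their two values can be compared. Compound 3 `CC(=O)c1cc(=O)oc2cc(OCc3cccc(Cl)c3)ccc12` differs from compound 1 in one place: acetyl in place of isopropoxy on an aromatic carbon. Within the data shown here, no measured pair shows what such a change does here, so the expectation is loose. The expected step is a number 12 percentage points higher from compound 1 to compound 3 (beyond the scatter), small and upward. Compound 3 is therefore estimated at 15%, within a range from 0% to 40%.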

Compound 3, a percentage reported as inhibition, at one concentration (the size of the read-out at that concentration, not a potency): 0%
Beside the measured number, compound 3's estimate is 15 percentage points above it; the range from low to high includes it.
By their numbers in this assay, from the lowest: compounds 3 and 1 (each within the scatter of the next); then compound 2.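

In this assay, acetyl in place of isopropoxy on this aromatic carbon, opposite the ring oxygen, gives a number 3 percentage points lower from compound 1 to compound 3 (within the scatter), so this change does not measurably alter the read-out. Inhibition stays low with either group, and adding a double bond outside the aromatic rings while removing one heavy atom brings no detectable gain here. Nothing available explains this result.

On these data alone, whether an amine, a carboxylic acid or a longer chain at this position would raise the number remains open.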